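The compounds below may be only part of what the source reports. "The series", "measured", "known", "first", "only" and "open" are said of these compounds alone.

Of the compounds shown here, three sharing one core have been measured in an ADME assay on L929 cells (Mus musculus) for cytotoxicity, read by resazurin assay, with a stated time of 72 h; on this read-out lower numbers stand for stronger inhibition and higher numbers for weaker inhibition. Compound 1 `CC(=O)c1ccn(-c2ccc3c(c2)B(O)OC3)c1` is reported only as a limit of the assay, > 10 ug/mL. Compound 2 `Nc1ccc(C(=O)c2ccn(-c3ccc4c(c3)B(O)OC4)c2)cc1` gives 3.9 ug/mL. Compound 3 `CCCC(=O)c1ccn(-c2ccc3c(c2)B(O)OC3)c1` likewise stands at a limit, > 10 ug/mL. Two steps can be read: an at least 2.5-fold lower number from compound 1 to compound 2 (0.40 log units; beyond the scatter) and an at least 2.5-fold higher number from compound 2 to compound 3 (0.40 log units; beyond the scatter). The step that the two limits leave unreadable from compound 1 to compound 3 cannot be sized because both ends sit at the limit of > 10 ug/mL in this assay, at which 2 of the 3 values shown sit. Compound 4 `O=C(c1ccn(-c2ccc3c(c2)B(O)OC3)c1)C1CCCCC1` differs from compound 3 by cyclohexyl in place of propyl on a carbonyl carbon. Since the methyl of compound 1 and the propyl of compound 3 both leave the number at the assay limit, compound 4 is expected to give a step that the limit leaves unreadable from compound 3 to compound 4. Compound 4 is estimated at 15 ug/mL, within 5 ug/mL to 40 ug/mL.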

Compound 4, half-maximal inhibitory concentration: > 10 ug/mL
Compound 4: no number, only a limit (the forecaster's own chance of this, stated with the estimate: 70%); the middle value lies beyond the limit too.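

In this assay, cyclohexyl on the carbonyl carbon also gives only a limit, so a six-membered non-aromatic ring of carbon does not reproduce the result of 4-aminophenyl, with an at least 2.5-fold higher number from compound 2 to compound 4 (0.40 log units; beyond the scatter). Among the four compounds, only compound 2 gives a number. The steps from compound 1 and compound 3 to compound 4 cannot be read because both ends of each sit at a limit: the limit of > 10 ug/mL in this assay, at which 3 of the 4 values shown sit.

Going by these compounds, it remains open whether the amine or the phenyl ring of compound 2 matters more. Plain phenyl or an aminocyclohexyl on the carbonyl carbon would separate the two.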